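The compounds below may be only part of what the source reports. "The series", "measured", "known", "first", "only" and "open" are said of these compounds alone.

The study concerns a shared core, an acetylsalicylate carried on an acyloxymethyl carbonate, to which differing tails are attached. Compound 1 `CC(=O)Oc1ccccc1C(=O)OCOC(=O)OCCOc1ccc(-c2cc(=S)ss2)cc1`, compound 2 `CC(=O)Oc1ccccc1C(=O)OCOC(=O)Oc1ccc(CCCO[N+](=O)[O-])cc1`, and compound 3 `CC(=O)Oc1ccccc1C(=O)OCOC(=O)OCCCO[N+](=O)[O-]` have been measured; compound 4 `CC(=O)Oc1ccccc1C(=O)OCOC(=O)Oc1ccc(CC(CO[N+](=O)[O-])O[N+](=O)[O-])cc1` has not.

In an ADME assay on the whole organism (serum) for metabolic stability, with Homo sapiens as the target, read by HPLC, tested at 200 uM (on this read-out higher numbers stand for a longer-lived compound and lower numbers for a shorter-lived compound), compound 1 gives 0.05 h. In this assay compound 2 gives 0.0267 h, and the two numbers lie within the usual scatter of one another. For compound 3 the result in this assay is a limit of the assay rather than a number, < 0.0167 h, as noted in the limit of < 0.0167 h in this assay, at which 1 of the 3 values shown sits.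

Compound 4 differs from compound 2 in one place: nitrooxy in place of hydrogen on a saturated chain carbon bound to two saturated chain carbons. For the measured compounds named here, no step between measured compounds bears on this change, so the account rests on the values of compound 2 alone. The account expects the step of a 1.1-fold lower number from compound 2 to compound 4 (0.03 log units; within the scatter) to stay within the scatter, with no direction to it. Compound 4 is therefore estimated in this assay at 0.025 h, with a range from 0.013 h to 0.05 h.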

Compound 4, half-life in the Homo sapiens assay: 0.0367 h
For compound 4 the middle estimate is 1.5-fold (0.17 log units) below the measured one, and the stated range covers the measured number.
By their numbers in the Homo sapiens assay, from the lowest: compounds 2, 4 and 1 (each within the scatter of the next). At a limit, below all of these: compound 3.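

In the Homo sapiens assay the added nitrooxy, on a saturated chain carbon bound to two saturated chain carbons, gives a 1.4-fold higher number from compound 2 to compound 4 (0.14 log units; within the scatter), so at this position the second nitrooxy leaves the two half-lives indistinguishable. In a physicochemical assay, read by HPLC, in phosphate buffer, with a stated time of 3 h, at pH 7.4 (a higher number here means that more of the compound is left, a lower number that less of the compound is left), compound 2 has 98% remaining and compound 4 has 95% remaining, and with a number 3 percentage points lower from compound 2 to compound 4 (within the scatter) the two compounds also cannot be told apart in phosphate buffer. Nothing measured here explains why this change gives no readable difference in either assay.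

The compounds shown leave open whether a hydroxyl or an amine at this same place would give a half-life that stands apart from that of compound 2 in the Homo sapiens assay. They also leave open whether the same nitrooxy would read the same way on the tail of compound 3.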